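Acetoxymethyl for chloro on the fused core

A few compounds are considered here, and "the series" means these few. Any claim that something is new, unique, unknown or untested is made for them only; others in the source may bear on it.

Measured compounds:
Compound 1, `CC(=O)c1c(C)nc2c(OCc3ccccc3)cccn12`, 57%
Compound 2, `Cc1nc2c(OCc3ccccc3)cccn2c1CO`, 99%
Compound 3, `Cc1nc2c(OCc3ccccc3)cccn2c1Cl`, 93%

In a functional assay on the whole organism with Rattus norvegicus as the target, with a stated time of 4 h, at a dose of 40 mg/kg by the intraperitoneal route (on this read-out lower numbers stand for less inhibition and higher numbers for more inhibition at the one dose given (going by the name of the read-out)), compound 3 stands second highest of the three measured numbers; compound 2 is within the scatter of it, a number 6 percentage points lower from compound 2 to compound 3 (within the scatter), while compound 1 lies well below, a number 36 percentage points higher from compound 1 to compound 3 (beyond the scatter). The unmeasured compound 4, `CC(=O)OCc1c(C)nc2c(OCc3ccccc3)cccn12`, differs from compound 3 by acetoxymethyl in place of chloro on an aromatic carbon. Among the compounds with values here, two measured steps bear on this change: the step of a number 36 percentage points higher from compound 1 to compound 3 (beyond the scatter) and the step of a number 42 percentage points higher from compound 1 to compound 2 (beyond the scatter) were large, whereas the step of a number 6 percentage points lower from compound 2 to compound 3 (within the scatter) was not beyond the scatter. Replacing chloro with hydroxymethyl did not shift the number beyond the scatter, so a replacement by acetoxymethyl is expected to leave compound 4 near compound 3, with the possibility of a modest fall. The step from compound 3 to compound 4 is therefore estimated as a number 8 percentage points lower from compound 3 to compound 4 (within the scatter). Compound 4 is expected to give 85%, with a range from 60% to 99%.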

Compound 4, a percentage reported as inhibition, in the whole organism at one dose (the size of the read-out at that dose, not a potency): 88%
Compound 4: middle estimate off by 3 percentage points, on the low side; the range from low to high includes it.
By their numbers in this assay, from the lowest: compound 1; then compounds 4, 3 and 2 (each within the scatter of the next, the first and the last beyond it).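

In this assay this carbon of the five-membered aromatic ring accepts acetoxymethyl, with 5 heavy atoms and 2 hydrogen-bond acceptors, in place of a single chlorine, as a number 5 percentage points lower from compound 3 to compound 4 (within the scatter) shows. Acetyl on the oxygen of the hydroxymethyl group does have a small cost, with a number 11 percentage points lower from compound 2 to compound 4 (beyond the scatter) and thus a step beyond the scatter that chloro in place of hydroxymethyl did not give, yet the ester stays well clear of the ketone, with a number 31 percentage points higher from compound 1 to compound 4 (beyond the scatter) as the measure of that gap. Nothing given here explains these steps.

On these data alone, whether an amine, a carboxylic acid or a longer ester chain on this carbon would keep the number up remains open. The compounds shown also leave open what happens when the methyl group on the ring atom that bears it is replaced by ethyl or hydrogen.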